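Replacing Methyl with Dimethylamino in Compound 4

This account rests on a few compounds, and the source may have more. Where it says the series, first, only, none or still open, it means among the compounds named here.

compound 1 `Cc1cc(Nc2cc(Cl)cc(Cl)c2)ncn1`: > 180000 nM, a limit of the assay
compound 2 `Cc1cc(N(C)c2cc(Cl)cc(Cl)c2)nc(N)n1`: > 180000 nM, a limit of the assay
compound 3 `Cc1cc(Nc2cc(Cl)c(C)c(Cl)c2)nc(N)n1`: > 63000 nM, a limit of the assay

Among the compounds with values here, in an assay on cells for inhibition of S-adenosylmethionine decarboxylase proenzyme (Homo sapiens), read by mass spectrometry, at pH 7.2 (a higher number here means a weaker inhibitor, a lower number a stronger inhibitor), every value so far is a limit rather than a number. Compound 3 stands at a limit, > 63000 nM, with no measured number beneath it. The two further values are limits as well, one at the limit of > 180000 nM in this assay, at which 2 of the 3 values shown sit, and one at the limit of > 63000 nM in this assay, at which 1 of the 3 values shown sits. Compound 4 `Cc1cc(Nc2cc(Cl)c(N(C)C)c(Cl)c2)nc(N)n1` differs from compound 3 by dimethylamino in place of methyl on an aromatic carbon. Within the data shown here, no step between measured compounds is available, so nothing measured sets the size of this change; with every value a limit, the expectation is no movement beyond the scatter in this assay, and the expected step is a step that the limit leaves unreadable from compound 3 to compound 4. Compound 4 is therefore estimated at 150000 nM, in a range from 30000 nM to 600000 nM.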

Compound 4, half-maximal inhibitory concentration: > 180000 nM
Compound 4: a limit, no number; the forecaster's own chance of this, stated with the estimate: 80%; at least 1.2-fold (0.07 log units) between middle value and limit.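

Compound 3 and compound 4 both give only limits of the assay, and the step between them cannot be read. The compounds shown leave open whether dimethylamino in place of methyl on an aromatic carbon changes inhibition at all.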